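The source may hold more compounds than are shown below. What is called first, only, known or untested is meant among the compounds shown, and "the series" means these compounds.

Measured compounds:
compound 1, `COc1ccccc1N1CCN(CCCNC(=O)NN(Cc2ccccc2F)c2ccc(Cl)cc2)CC1`, 2.6 nM
compound 2, `COc1ccccc1N1CCN(CCCNC(=O)NN(Cc2ccccc2F)c2ccc(Br)cc2)CC1`, 3.3 nM
compound 3, `O=C(NCCCN1CCN(c2ccc(Cl)cc2)CC1)NN(Cc1ccccc1)c1ccccc1`, 9.7 nM

The three compounds were compared in an assay on CHO cells for displacement of a labelled ligand from D(4) dopamine receptor (Homo sapiens), read by radioligand binding; on this read-out lower numbers stand for stronger inhibition and higher numbers for weaker inhibition. Compound 1 gives 2.6 nM, and compound 2 gives 3.3 nM. The two share a core and differ only in one place: bromo in place of chloro on an aromatic carbon. That change made a 1.3-fold higher number from compound 1 to compound 2 (0.10 log units; within the scatter), so the two numbers cannot be told apart. Compound 3, with 9.7 nM, gives the highest number of the three, and its gaps to compound 1 and to compound 2 both lie beyond the usual scatter. How the core of compound 3 differs from the core of compound 1 is not broken down here.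

Compound 4, `O=C(NCCCN1CCN(c2ccc(Br)cc2)CC1)NN(Cc1ccccc1)c1ccccc1`, has not yet been measured in this assay. It is derived from compound 3 by the same change that links compound 1 to compound 2: bromo in place of chloro on an aromatic carbon. The place is the same in both pairs, so this is the same change on a different core.

Because the same change made a 1.3-fold higher number from compound 1 to compound 2 (0.10 log units; within the scatter), compound 4 is expected to stay close to compound 3, and the step is estimated as a 1.2-fold higher number from compound 3 to compound 4 (0.09 log units; within the scatter). On that basis compound 4 is expected to give about 12 nM in this assay. Allowing for the usual spread of repeated measurements, compound 4 is estimated to fall between 6 nM and 25 nM.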

Compound 4, inhibition constant: 14 nM
Compound 4: the middle estimate sits 1.2-fold (0.07 log units) below what was measured; the measured number falls inside the stated range.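

In this assay, putting bromo in place of chloro on the aromatic carbon gave a 1.4-fold higher number from compound 3 to compound 4 (0.16 log units; within the scatter), so the two numbers cannot be told apart. Set beside the earlier pair, the change reads the same on both cores: the same change on two cores in this assay, a 1.3-fold higher number (0.10 log units; within the scatter) from compound 1 to compound 2 and a 1.4-fold higher number (0.16 log units; within the scatter) from compound 3 to compound 4, 1.1-fold (0.06 log units) apart, within the scatter of two such steps This shows that, on these two cores and in this one assay, going from chloro to bromo at this place left the number within the usual scatter, so the earlier step was a fair guide to the new one; it does not show that the same would hold on any other core or in any other assay, and two pairs are too few to establish a rule for the series.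

The compounds shown carry only chloro or bromo at the place that changed, so it remains open what a trifluoromethyl group, a nitrile or a plain hydrogen would do there. As far as these compounds go, it is also open whether the exchange of chloro for bromo would stay just as quiet on a core with a longer chain or with a carboxylic acid added to it.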